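This account rests on a few compounds, and the source may have more. Where it says the series, first, only, none or still open, it means among the compounds named here.

Compound 1 `N=C(N)NCCC[C@H](NC(=O)CN(c1ncnc2c1ncn2C1CCCCO1)C1CC1)C(=O)OCc1ccccc1` belongs to a small set of three related amides built on a shared core. In a functional assay on the whole organism (Tail, strain ICR) with Mus musculus as the target, in the tail flick test, with a stated time of 60 min, at a dose of 25 umol/kg by the oral route (on this read-out lower numbers stand for a weaker effect and higher numbers for a stronger effect at the one dose given), compound 1 gives 52.4%, the highest of the three numbers. Compound 2 `CSCC[C@H](NC(=O)CN(c1nc(Cl)nc2[nH]cnc12)C1CC1)C(=O)OCc1ccccc1` gives 30.8% and compound 3 `O=C(CN(c1nc(Cl)nc2[nH]cnc12)C1CC1)N[C@@H](CC(=O)OCc1ccccc1)C(=O)OCc1ccccc1` gives 22.4%. Within the data shown here, the only step measured so far between two compounds that differ in one place is a number 8.4 percentage points lower from compound 2 to compound 3 (within the scatter), so a swap of side chain at that carbon left the read-out essentially unchanged. Compound 4 `C[C@H](NC(=O)CN(c1ncnc2c1ncn2C1CCCCO1)C1CC1)C(=O)OCc1ccccc1` differs from compound 1 by a hydrogen atom in place of a group of 6 heavy atoms (3 carbon, 3 nitrogen; no ring), on a saturated chain carbon, two bonds along the chain from an amide-type nitrogen and a carbonyl carbon. Among the measured compounds shown here, no measured step removes a whole side chain at that carbon, so the expectation rests loosely on the step from compound 2 to compound 3: compound 4 is estimated at 40% (range 22% to 58%), a step of a number 12.4 percentage points lower from compound 1 to compound 4 (beyond the scatter) expected.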

Compound 4, a percentage reported as activity, at one dose (the size of the read-out at that dose, not a potency): 53%
Compound 4: the middle estimate sits 13 percentage points below what was measured; low and high end bracket the measured number.
By their numbers in this assay, from the lowest: compounds 3 and 2 (each within the scatter of the next); then compounds 1 and 4 (each within the scatter of the next).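

In this assay, a hydrogen atom in place of the group of 6 heavy atoms gives a number 0.6 percentage points higher from compound 1 to compound 4 (within the scatter). The earlier step only exchanged one side chain for another, whereas this one shows that, on the core of compound 1, the read-out at this one dose does not depend on keeping that whole group on this saturated chain carbon. No evidence here explains this result.

As far as these compounds go, it remains open whether a side chain ending in an amine or a carboxylic acid would shift the number. The same holds for a longer plain carbon chain at this carbon.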